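Replacing the dimethoxyphenyl ring with a dibromohydroxyphenyl ring

A few compounds are considered here, and "the series" means these few. Any claim that something is new, unique, unknown or untested is made for them only; others in the source may bear on it.

Compound 3 `COc1ccc(/C=C/C(=O)Nc2cc3c(Nc4ccc(F)c(Cl)c4)ncnc3cc2O[C@H]2CCOC2)c(OC)c1` gives 28600 nM in a functional assay on MCF7 cells (Homo sapiens) for cytotoxicity, read by MTT assay, with a stated time of 72 h (a lower number here means a stronger inhibitor, a higher number a weaker inhibitor), the lowest of the three numbers measured, though within the scatter of both neighbours: compound 2 `COc1cc(/C=C/C(=O)Nc2cc3c(Nc4ccc(F)c(Cl)c4)ncnc3cc2O[C@H]2CCOC2)cc(OC)c1` gives 30300 nM and compound 1 `COc1ccc(OC)c(/C=C/C(=O)Nc2cc3c(Nc4ccc(F)c(Cl)c4)ncnc3cc2O[C@H]2CCOC2)c1` gives 36300 nM. The measured steps of a 1.2-fold lower number from compound 1 to compound 2 (0.08 log units; within the scatter), a 1.3-fold lower number from compound 1 to compound 3 (0.10 log units; within the scatter) and a 1.1-fold lower number from compound 2 to compound 3 (0.03 log units; within the scatter) all move the methoxy groups around the same ring and stay within the scatter. Compound 4 `O=C(/C=C/c1cc(Br)c(O)c(Br)c1)Nc1cc2c(Nc3ccc(F)c(Cl)c3)ncnc2cc1O[C@H]1CCOC1` carries a different change: 3,5-dibromo-4-hydroxyphenyl in place of 2,4-dimethoxyphenyl on a double-bonded chain carbon bound to a double-bonded chain carbon. No measured step exchanges the ring itself, so nothing shown predicts the direction; the expected step of a 1.1-fold lower number from compound 3 to compound 4 (0.06 log units; within the scatter) is therefore small. Compound 4 is estimated at 25000 nM in this assay, with a range from 7000 nM to 90000 nM.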

Compound 4, half-maximal inhibitory concentration: 30600 nM
The estimate for compound 4 lay 1.2-fold (0.09 log units) below the measured number; measured number inside the range.
By their numbers in this assay, from the lowest: compounds 3, 2, 4 and 1 (each within the scatter of the next).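

Exchanging the dimethoxyphenyl ring itself for 3,5-dibromo-4-hydroxyphenyl, and not only moving its methoxy groups, stays within the scatter in this assay against all three dimethoxyphenyl compounds (a 1.1-fold higher number from compound 3 to compound 4 (0.03 log units; within the scatter)), (a 1.0-fold higher number from compound 2 to compound 4 (0.00 log units; within the scatter)) and (a 1.2-fold lower number from compound 1 to compound 4 (0.07 log units; within the scatter)). At this position, the ring with bromine and hydroxyl therefore reads the same as the rings with two methoxy groups. No evidence is available to explain this result.

On these data alone, whether an amine or a carboxylic acid on this ring would move the number beyond the scatter remains open. So does the effect of a longer chain between this ring and the amide carbonyl.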